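The source may hold more compounds than are shown below. What is called first, only, known or untested is meant among the compounds shown, and "the series" means these compounds.

Compound 1 `Cc1ccc(OCc2cn(Cc3ccc(Cl)cc3)nn2)cc1` and compound 2 `Cc1ccc(OCc2cn(Cc3cccc(Cl)c3)nn2)cc1` share one core and differ in a single place. In an ADME assay on PANC-1 cells (Homo sapiens) for inhibition, read by MTT assay, with a stated time of 48 h (a lower number here means a stronger inhibitor of growth, a higher number a weaker inhibitor of growth), compound 1 gives only a limit, > 100 ug/mL. In the same assay compound 2 also gives only a limit, > 100 ug/mL. The step that the two limits leave unreadable from compound 1 to compound 2 therefore has no readable size, since both values rest on (the limit of > 100 ug/mL in this assay, at which 2 of the 2 values shown sit). Compound 3 `Clc1ccc(OCc2cn(Cc3cccc(Cl)c3)nn2)cc1` arises from compound 2 by chloro in place of methyl on an aromatic carbon. Among the compounds with values here, no measured step bears on this change, so the expected step is a step that the limit leaves unreadable from compound 2 to compound 3, nothing beyond the scatter. Compound 3 is thus estimated at 150 ug/mL, within 50 ug/mL to 450 ug/mL.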

Compound 3, concentration for 50% growth inhibition: > 100 ug/mL
Compound 3: a limit, no number; the forecaster's own chance of this, stated with the estimate: 80%; the middle value lies beyond the limit too.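

No step can be read from compound 2 to compound 3, because each gives only a limit: the limit of > 100 ug/mL in this assay, at which 3 of the 3 values shown sit.

On these data alone, how strongly compound 1, compound 2 or compound 3 inhibits growth stays open, as does any effect of chloro in place of methyl.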